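The source may report more compounds than this note shows. Statements on the series, on what has been measured and on what is new or still open speak of the compounds shown alone.

In a physicochemical assay for solubility, using the shake flask method, in phosphate buffer, measured as kinetic solubility, with a stated time of 20 h, at pH 6.5 (on this read-out higher numbers stand for higher solubility and lower numbers for lower solubility), compound 1 `Fc1ccc(-c2nc3cnc(Nc4ccccn4)cc3[nH]2)cc1F` gives < 5000 nM, which is a limit and not a number. Compound 2 `Fc1ccc(-c2nc3cnc(Nc4ccc(C(F)(F)F)cn4)cc3[nH]2)cc1F` gives < 5000 nM, which is also only a limit. Both compounds sit at the same boundary, (the limit of < 5000 nM in this assay, at which 2 of the 2 values shown sit). Compound 3 `Fc1ccc(Nc2cc3[nH]c(-c4ccc(F)c(F)c4)nc3cn2)nc1` carries fluoro in place of trifluoromethyl on an aromatic carbon, two atoms from the ring nitrogen. Since a step that the two limits leave unreadable from compound 1 to compound 2 has no readable size, no shift beyond the scatter is expected in this assay. The estimated step is a step that the limit leaves unreadable from compound 2 to compound 3. For compound 3 the expected solubility is 2500 nM, with an estimated range of 800 nM to 5000 nM.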

Compound 3, solubility: < 5000 nM
Compound 3 ended at the assay's limit (the forecaster's own chance of this, stated with the estimate: 85%); the middle value lies beyond the limit too.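

No step can be read among compound 1, compound 2 and compound 3, since all three give only a limit and not a number: the limit of < 5000 nM in this assay, at which 3 of the 3 values shown sit. On these data alone, the actual solubility of each compound stays open, as does whether hydrogen, fluoro or trifluoromethyl at that aromatic carbon makes any difference to it.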